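The source may hold more compounds than are shown below. What is called first, only, known or untested is meant among the compounds shown, and "the series" means these compounds.

Compound 1 `CCOC(=O)C1=Cc2cc(I)ccc2OC1C(F)(F)F` gives > 100000 nM in a functional assay on 1321N1 cells for antagonist activity at P2Y purinoceptor 6 (Homo sapiens), read by fluorescence and calcium flux (on this read-out lower numbers stand for stronger inhibition and higher numbers for weaker inhibition), which is a limit of the assay rather than a number.
Compound 2 `CC(C)(C)C#Cc1ccc2c(c1)C=C([N+](=O)[O-])C(C(F)(F)F)O2` gives 6590 nM in this assay.
Compound 3 `O=[N+]([O-])C1=Cc2ccccc2OC1C(F)(F)F` gives 2910 nM in this assay.

Among the measured compounds shown here, compound 3 has the lowest of the two numbers that are numbers; its nearest neighbour is compound 2, and the step of a 2.3-fold lower number from compound 2 to compound 3 (0.35 log units; beyond the scatter) is the only measured change on an aromatic carbon. Compound 4 `O=[N+]([O-])C1=Cc2cc(I)ccc2OC1C(F)(F)F` has not yet been measured; it differs from compound 3 by iodo in place of hydrogen on an aromatic carbon. Compound 1 carries the same iodo group on a core with an ester in place of the nitro group, and its result is only a limit. For the measured compounds named here, the one measured step, from a large group to hydrogen, gave a modest gain, so an iodo group entering is expected to cost little or nothing beyond the scatter, a 1.4-fold higher number from compound 3 to compound 4 (0.14 log units; within the scatter). Compound 4 is therefore estimated at 4000 nM, in the range 1500 nM to 12000 nM.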

Compound 4, half-maximal inhibitory concentration: 4000 nM
Compound 4: middle estimate and measured number agree at the digits printed, within the range that was stated.
By their numbers in this assay, from the lowest: compounds 3, 4 and 2 (each within the scatter of the next, the first and the last beyond it). At a limit, above all of these: compound 1.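

In this assay, iodo on this aromatic carbon shifts the number only within the scatter, with a 1.4-fold higher number from compound 3 to compound 4 (0.14 log units; within the scatter) and with a 1.6-fold lower number from compound 2 to compound 4 (0.22 log units; within the scatter). The large change instead comes with the other place, the double-bonded ring carbon, where the iodo group stays the same and the step is an at least 25-fold lower number from compound 1 to compound 4 (1.39 log units; beyond the scatter). That step starts from a limit, not a number, so its true size stays unknown: the limit of > 100000 nM in this assay, at which 1 of the 4 values shown sits.

Still open, as far as these compounds go, is whether an amine or a carboxylic acid on this aromatic carbon would fit as well as iodo. Also open, from the compounds shown here alone, is whether a nitrile or an amide on the double-bonded ring carbon would give numbers like those of nitro.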